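A Bulkier Sulfur-Bearing Group Replaces the Nitrile-Bearing Ring

The compounds below may be only part of what the source reports. "The series", "measured", "known", "first", "only" and "open" are said of these compounds alone.

Among the measured compounds shown here, compound 1 `N#Cc1ccccc1C1OCC(C/C=C\CCC(=O)O)C(c2cccnc2)O1` gives 54 nM in an assay for inhibition of Thromboxane-A synthase (Homo sapiens), using microsomes (a lower number here means a stronger inhibitor, a higher number a weaker inhibitor), the lower of the two numbers measured so far, while compound 2 `O=C(O)CC/C=C\CC1COC(c2ccco2)OC1c1cccnc1` gives 164 nM. Compound 3 `CC(C)(Sc1ccccc1)C1OCC(C/C=C\CCC(=O)O)C(c2cccnc2)O1` differs from compound 1 at the same position that separates compounds 1 and 2: a group of 10 heavy atoms (9 carbon, 1 sulfur; one six-membered aromatic ring of carbon only) in place of a group of 8 heavy atoms (7 carbon, 1 nitrogen; one six-membered aromatic ring of carbon only), on a saturated ring carbon. Because a 3.0-fold higher number from compound 1 to compound 2 (0.48 log units; beyond the scatter) showed that replacing the group on this saturated ring carbon weakened inhibition modestly, compound 3 is expected to move in the same direction by a similar amount, a 2.8-fold higher number from compound 1 to compound 3 (0.44 log units; beyond the scatter). Compound 3 is therefore estimated at 150 nM, with a likely range from 50 nM to 500 nM.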

Compound 3, half-maximal inhibitory concentration: 40 nM
Compound 3: middle estimate off by 3.8-fold (0.57 log units), on the high side, and the stated range ends above it.
By their numbers in this assay, from the lowest: compounds 3 and 1 (each within the scatter of the next); then compound 2.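

The carbon between the two ring oxygen atoms accepts a much larger group without a measurable loss: the sulfur-bearing group leaves inhibition unchanged, with a 1.4-fold lower number from compound 1 to compound 3 (0.13 log units; within the scatter). The earlier drop with furan-2-yl therefore does not mean that any replacement of 2-cyanophenyl weakens inhibition, and the new group also recovers ground against that compound, with a 4.1-fold lower number from compound 2 to compound 3 (0.61 log units; beyond the scatter). On these data alone, whether the sulfur atom matters, and how a plain phenyl group or an oxygen linker in place of sulfur would compare here, remains open. Nothing measured here explains why the numbers fall this way.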